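From Hexyl to Cyclohexyl on a Shared Core

The source may hold more compounds than are shown below. What is called first, only, known or untested is meant among the compounds shown, and "the series" means these compounds.

In a functional assay on MCF7 cells (Homo sapiens) for inhibition, read by fluorescence, with a stated time of 72 h (on this read-out higher numbers stand for weaker inhibition of growth and lower numbers for stronger inhibition of growth), compound 2 (`CCCCCCn1cnc2c(Nc3ccc(O)cc3)nc(N[C@H]3CC[C@H](N)CC3)nc21`) gives 3500 nM. Compound 3 (`CCCCCCn1cnc2c(Nc3cccc(Cl)c3)nc(N[C@H]3CC[C@H](N)CC3)nc21`) gives 2700 nM in this assay, and compound 1 (`N[C@H]1CC[C@H](Nc2nc(Nc3ccc(Cl)cc3)c3ncn(C4CCCCC4)c3n2)CC1`) gives 2300 nM. Compound 2 therefore stands within the scatter of both other compounds.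

Compound 4 (`N[C@H]1CC[C@H](Nc2nc(Nc3ccc(O)cc3)c3ncn(C4CCCCC4)c3n2)CC1`) departs from compound 2 at one place, with cyclohexyl in place of hexyl on an aromatic nitrogen. Going by the values given here, the only measured step, a 1.3-fold lower number from compound 2 to compound 3 (0.11 log units; within the scatter), concerns a different group, so it shows only how little the numbers moved with that other change. Among the compounds with values here, no measured pair isolates the exchange of hexyl for cyclohexyl. The closest evidence is compound 1, which carries cyclohexyl on that nitrogen and gives 2300 nM, although it also differs from compound 4 in another group. No step beyond the scatter is therefore expected in this assay. The expected step is a 1.2-fold lower number from compound 2 to compound 4 (0.07 log units; within the scatter). Compound 4 is estimated at 3000 nM, with an expected range from 1300 nM to 7000 nM.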

Compound 4, concentration for 50% growth inhibition: 9600 nM
Beside the measured number, compound 4's estimate is 3.2-fold (0.51 log units) below it; measured number outside the range, above it.
By their numbers in this assay, from the lowest: compounds 1, 3 and 2 (each within the scatter of the next); then compound 4.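

In this assay, the substituent on the aromatic nitrogen proves to matter: with the same number of heavy atoms, cyclohexyl in place of hexyl gives a 2.7-fold higher number from compound 2 to compound 4 (0.44 log units; beyond the scatter). The earlier compounds shown here showed no step beyond the scatter, and this change now shows that a ring and a chain are not interchangeable at this position when the hydroxy group is present. The cyclohexyl pair adds a second step beyond the scatter, with hydroxy in place of chloro on an aromatic carbon giving a 4.2-fold higher number from compound 1 to compound 4 (0.62 log units; beyond the scatter), so that exchange also counts on this background. Nothing presented here explains either step. From the compounds shown here alone, it remains open whether cyclohexyl and hexyl would differ in the same direction with chloro in place of hydroxy. Going by these compounds, how a cyclopentyl group or a shorter butyl chain on that nitrogen would read also remains open.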